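The source may hold more compounds than are shown below. What is called first, only, known or untested is meant among the compounds shown, and "the series" means these compounds.

Series notes, shared core held constant; the amide substituent on the saturated chain carbon is varied.

In an ADME assay on BE(2)-C cells (Homo sapiens) for cytotoxicity, read by MTT assay, with a stated time of 20 h (on this read-out higher numbers stand for lower toxicity in this test and lower numbers for higher toxicity in this test), compound 1 `O=C(NCc1ccncc1)C1CCN(C(=O)c2cc3ccccc3n2Cc2ccc(Cl)cc2)CC1` gives only a limit, > 100000 nM. Compound 2 `CN1CCC(CNC(=O)C2CCN(C(=O)c3cc4ccccc4n3Cc3ccc(Cl)cc3)CC2)CC1` likewise gives only a limit in this assay, > 50000 nM. Going by the values given here, compound 3 `O=C(NCC1COc2cnccc21)C1CCN(C(=O)c2cc3ccccc3n2Cc2ccc(Cl)cc2)CC1` is the one compound with a number in this assay, 75800 nM. Compound 2 thus stands at the limit marked by the limit of > 50000 nM in this assay, at which 1 of the 3 values shown sits, and the steps that touch it are a step that the two limits leave unreadable from compound 1 to compound 2 and a step that the limit leaves unreadable from compound 2 to compound 3. Among the compounds with values here, the one readable step is an at least 1.3-fold lower number from compound 1 to compound 3 (0.12 log units; that floor lies within the scatter).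

Compound 4 `CN(Cc1ccccc1)C(=O)C1CCN(C(=O)c2cc3ccccc3n2Cc2ccc(Cl)cc2)CC1` carries the change (benzyl(methyl)amino in place of ((1-methylpiperidin-4-yl)methyl)amino on a carbonyl carbon). Within the data shown here, neither step from compound 2 yields a size, and the only readable step in the set lies within the scatter, so no direction beyond the scatter is expected for the step from compound 2 to compound 4 in this assay; a value near the upper reach of the assay is expected, with a fair chance that only a limit is returned. Compound 4 is estimated at 60000 nM, between 20000 nM and 150000 nM. The step this estimate implies is a step that the limit leaves unreadable from compound 2 to compound 4, expected to stay within the scatter.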

Compound 4, half-maximal cytotoxic concentration: 87000 nM
The estimate for compound 4 lay 1.5-fold (0.16 log units) below the measured number, within the range that was stated.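

Compound 4 shows that in this assay the carbonyl carbon can carry benzyl(methyl)amino, a group with no hydrogen-bond donor, no hydrogen-bond acceptor and a six-membered aromatic ring of carbon only, without a change beyond the scatter from compound 3: the swap gives a 1.1-fold higher number from compound 3 to compound 4 (0.06 log units; within the scatter). Against compound 1, the swap gives an at least 1.1-fold lower number from compound 1 to compound 4 (0.06 log units; that floor lies within the scatter), and only that floor can be read. The step from compound 2 to compound 4 cannot be read because compound 2 gives only a limit: the limit of > 50000 nM in this assay, at which 1 of the 4 values shown sits.

The compounds shown leave open whether any substituent at this carbonyl carbon lowers the number beyond the scatter. A carboxylic acid, a primary amine or a longer chain ending in the same phenyl ring would test this, and dimethylamino would show whether the benzyl group matters at all.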